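Swapping One Hydroxy Group for Acetoxy

The compounds below may be only part of what the source reports. "The series", "measured", "known", "first", "only" and "open" are said of these compounds alone.

Among the compounds with values here, only two compounds have numbers so far. In a functional assay on NCI-H23 cells (Homo sapiens) for cytotoxicity, read by luminescence and CellTiter-Glo, with a stated time of 72 h (on this read-out lower numbers stand for stronger inhibition and higher numbers for weaker inhibition), compound 1 `O=C1C=CC[C@@H]([C@H](O)[C@H](O[C@@H](c2ccccc2)[C@@H](O)[C@@H]2CC=CC(=O)O2)c2ccccc2)O1` gives 3200 nM, and compound 2 `O=C1C=CC[C@@H]([C@H](O)[C@@H](O[C@H]([C@@H]2CC=CC(=O)O2)[C@@H](O)c2ccccc2)c2ccccc2)O1` gives 5200 nM. Within the data shown here, these two values lie within the usual scatter of repeated measurements, so compound 1 sits level with the only other measured compound and neither can be ranked above the other. Both numbers are in the low micromolar range.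

The next molecule, compound 3 `CC(=O)O[C@@H]([C@@H]1CC=CC(=O)O1)[C@H](O[C@@H](c1ccccc1)[C@@H](O)[C@@H]1CC=CC(=O)O1)c1ccccc1`, is built from compound 1 by a single edit: acetyl in place of hydrogen on an oxygen on a saturated carbon. This is acetyl in place of hydrogen on an oxygen on a saturated carbon, or, read one bond further out, hydroxy to acetoxy. The rest of the structure stays the same.

Among the measured compounds shown here, no measured pair shows this change, so the data give no direct guide to its effect. The working expectation in this assay is therefore no shift beyond the scatter, in either direction. The estimated change is small: a 1.3-fold lower number from compound 1 to compound 3 (0.11 log units; within the scatter). For compound 3 the expected value is 2500 nM, with an estimated range from 800 nM to 8000 nM.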

Compound 3, half-maximal inhibitory concentration: 2600 nM
The estimate for compound 3 lay 1.0-fold (0.02 log units) below the measured number; the range from low to high includes it.
By their numbers in this assay, from the lowest: compounds 3, 1 and 2 (each within the scatter of the next).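

In this assay the swap of hydroxy to acetoxy gives a 1.2-fold lower number from compound 1 to compound 3 (0.09 log units; within the scatter) and this step lies within the scatter. The earlier compounds shown here formed no pair differing in one place, so they said nothing about any single position; this pair shows that the oxygen on this saturated carbon can carry an acetyl group, with its 3 heavy atoms, in place of hydrogen while the number stays level with that of compound 1. No measured information is available to explain why the two numbers stay level, and this one pair is all that speaks for the position.

The compounds shown leave open whether the same oxygen would tolerate a small methyl group as an ether, a longer chain such as hexanoyl, or a larger aromatic ester such as benzoyl, and whether a basic amine or a carboxylic acid carried on a chain there would move the number beyond the scatter. They also leave open whether acetyl in place of hydrogen on the remaining hydroxy of compound 3 would give a similar result.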